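The source may hold more compounds than are shown below. What is called first, only, known or untested is meant among the compounds shown, and "the series" means these compounds.

Measured compounds:
compound 1, `O=C(/C(=C\c1ccc(F)c([N+](=O)[O-])c1)S(=O)(=O)c1ccc(Br)cc1)c1ccc(Br)cc1`: 25000 nM
compound 2, `O=C(/C(=C\c1ccc(O)c([N+](=O)[O-])c1)SCc1ccc(Br)cc1)c1ccc(Cl)cc1Cl`: 10000 nM
compound 3, `O=C(/C(=C\c1ccc(O)c([N+](=O)[O-])c1)SCc1ccc(Br)cc1)c1ccc([N+](=O)[O-])cc1`: 10000 nM

In a functional assay on DU-145 cells (Homo sapiens) for inhibition, read by trypan blue exclusion, with a stated time of 96 h (on this read-out lower numbers stand for stronger inhibition of growth and higher numbers for weaker inhibition of growth), compound 1 gives the highest of the three numbers, and its distance to compound 2 and to compound 3 lies beyond the scatter in both cases. Within the data shown here, the single step that has been measured, no change at the digits printed from compound 2 to compound 3 (within the scatter), concerns the group on the carbonyl carbon and not the group on the chain.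

Compound 4, `O=C(/C(=C\c1ccc(F)cc1Cl)S(=O)(=O)c1ccc(Br)cc1)c1ccc(Br)cc1`, is not yet measured. It differs from compound 1 in 2-chloro-4-fluorophenyl in place of 4-fluoro-3-nitrophenyl on a double-bonded chain carbon bound to a double-bonded chain carbon. Among the measured compounds shown here, no measured pair changes the group on the double-bonded chain carbon, and the one step that exists, from compound 2 to compound 3, sits elsewhere and showed no change beyond the scatter. Nothing in the data therefore points in either direction for this step.

Compound 4 is accordingly expected to stay close to compound 1, with no change at the digits printed from compound 1 to compound 4 (within the scatter) estimated as no step beyond the scatter. The estimate for compound 4 in this assay is 25000 nM, within a range from 8000 nM to 70000 nM.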

Compound 4, concentration for 50% growth inhibition: 50000 nM
The estimate for compound 4 lay 2.0-fold (0.30 log units) below the measured number, and the stated range covers the measured number.
By their numbers in this assay, from the lowest: compounds 2 and 3 (each within the scatter of the next); then compounds 1 and 4 (each within the scatter of the next).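

In this assay, putting 2-chloro-4-fluorophenyl in place of 4-fluoro-3-nitrophenyl on a double-bonded chain carbon bound to a double-bonded chain carbon gives a 2.0-fold higher number from compound 1 to compound 4 (0.30 log units; within the scatter), the first step read at this position. On the core of compound 1, therefore, this exchange removes the nitro group and its 2 hydrogen-bond acceptors and brings in a chlorine, without a step beyond the scatter, though this single pair shows nothing about other groups or other cores. Nothing measured here gives a reason for this outcome.

On these data alone, whether a phenyl ring carrying an amine or a carboxylic acid at this position would give a step beyond the scatter remains open. So does the effect of this same exchange on the core of compound 2, which differs from compound 1 in more than one place.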